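The compounds below may be only part of what the source reports. "The series", "measured", "known", "first", "only" and "open" are said of these compounds alone.

In an assay on mitochondria for inhibition of Amine oxidase [flavin-containing] B (Bos taurus), read by fluorescence (a lower number here means a stronger inhibitor, a higher number a weaker inhibitor), the three measured compounds stand as follows:

compound 1, `O=C(NCCCCc1ccccc1)c1ccc[nH]1`, 57000 nM
compound 2, `CN(CCCCc1ccccc1)C(=O)c1ccc[nH]1`, 2500 nM
compound 3, `CC(NC(=O)c1ccc[nH]1)c1ccccc1`, 61800 nM

Compound 1 and compound 2 differ only in one place, (methyl in place of hydrogen on an amide-type nitrogen), and that change gave a 23-fold lower number from compound 1 to compound 2 (1.36 log units; beyond the scatter). Compound 3 carries the same amide and the same ring as compound 1, but how the two cores differ is not broken down here; their two values in this assay lie within the scatter of each other. Compound 4, `CC(c1ccccc1)N(C)C(=O)c1ccc[nH]1`, is not yet measured. Going by the values given here, it differs from compound 3 by methyl in place of hydrogen on an amide-type nitrogen, which is the same change, at a place described in the same words, as the one between compound 1 and compound 2. Because the earlier step was a 23-fold lower number from compound 1 to compound 2 (1.36 log units; beyond the scatter), the step from compound 3 to compound 4 is expected to be of comparable size, an 18-fold lower number from compound 3 to compound 4 (1.25 log units; beyond the scatter), though a single precedent leaves the expectation uncertain. For compound 4 the estimated value in this assay is 3500 nM, within 1000 nM to 15000 nM.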

Compound 4, inhibition constant: 4500 nM
Estimate against measurement, compound 4: 1.3-fold (0.11 log units) below, and the stated range covers the measured number.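

Methyl in place of hydrogen on the amide-type nitrogen gave a 14-fold lower number from compound 3 to compound 4 (1.14 log units; beyond the scatter) in this assay and so carried over to a second core. The two steps seen so far cannot be told apart in size: the same change on two cores in this assay, a 23-fold lower number (1.36 log units; beyond the scatter) from compound 1 to compound 2 and a 14-fold lower number (1.14 log units; beyond the scatter) from compound 3 to compound 4, 1.7-fold (0.22 log units) apart, within the scatter of two such steps. This shows that the change held on these two cores in this one assay, but it does not show that it would hold on other cores, and two steps alone do not explain it.

The compounds shown leave open whether ethyl or a longer chain on that nitrogen would give a step of like size. They also leave open whether the step would persist on a core carrying an amine or a carboxylic acid.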